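The compounds below may be only part of what the source reports. "The series", "measured", "known", "first", "only" and "open" are said of these compounds alone.

In a functional assay on THP-1 cells (Homo sapiens) (on this read-out higher numbers stand for weaker inhibition and lower numbers for stronger inhibition), compound 1 `CCSC[C@@](O)([C@@H](Nc1cccc2nc(C)ccc12)c1ccc(C)cc1)C(F)(F)F` gives 2.51 nM and compound 2 `CCSC[C@@](O)([C@@H](Nc1cccc2nc(C)ccc12)c1cccc(F)c1OC)C(F)(F)F` gives 2 nM, a step of a 1.3-fold lower number from compound 1 to compound 2 (0.10 log units; within the scatter). Compound 3 `CCSC[C@@](O)([C@@H](Nc1cccc2nc(C)ccc12)c1ccc(OC)c(F)c1)C(F)(F)F` gives 5.01 nM. That places it level with one neighbour, at a 2.0-fold higher number from compound 1 to compound 3 (0.30 log units; within the scatter), and separated from the other, at a 2.5-fold higher number from compound 2 to compound 3 (0.40 log units; beyond the scatter). Compound 4 `CCSC[C@@](O)([C@@H](Nc1cccc2nc(C)ccc12)c1ccc(Cl)c(F)c1OC)C(F)(F)F` brings (4-chloro-3-fluoro-2-methoxyphenyl in place of 3-fluoro-4-methoxyphenyl on a saturated chain carbon bound to a nitrogen on an aromatic ring and a saturated chain carbon). The entering group keeps the 3-fluoro and 2-methoxy of the 3-fluoro-2-methoxyphenyl in compound 2, so that last step is the closest guide, read in reverse. Within the data shown here, no measured compound here shows what the added chlorine does. In this assay the expected step is therefore modest, a 2.5-fold lower number from compound 3 to compound 4 (0.40 log units; beyond the scatter). For compound 4 the estimated value is 2 nM, with an expected range of 0.7 nM to 6 nM.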

Compound 4, half-maximal inhibitory concentration in the THP-1 assay: 1.59 nM
Compound 4: the middle estimate sits 1.3-fold (0.10 log units) above what was measured, and the stated range covers the measured number.
By their numbers in the THP-1 assay, from the lowest: compounds 4, 2, 1 and 3 (each within the scatter of the next, the first and the last beyond it).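

In the THP-1 assay the chlorine can now be read alone, and its step, a 1.3-fold lower number from compound 2 to compound 4 (0.10 log units; within the scatter), shows that this aromatic carbon takes chlorine with no change beyond the scatter. In the THP-1 assay the 4-chloro-3-fluoro-2-methoxyphenyl group also stays level with 4-methylphenyl, a 1.6-fold lower number from compound 1 to compound 4 (0.20 log units; within the scatter), while it clearly improves on 3-fluoro-4-methoxyphenyl, a 3.2-fold lower number from compound 3 to compound 4 (0.50 log units; beyond the scatter). That improvement comes with a much more lipophilic compound in a physicochemical assay for lipophilicity (a higher number here means a more lipophilic compound, a lower number a more polar compound), where compound 3 gives 4.1 and compound 4 gives 5.3: the measured partition coefficient of compound 3, 4.1, and of compound 4, 5.3, a number 1.20 log units higher (beyond the scatter)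

Going by these compounds, whether a nitrile or a hydroxyl group in place of the chlorine would keep the number in the THP-1 assay while lowering the number in the physicochemical assay remains open.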